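From bromo to methyl: an estimate for compound 4

The source may hold more compounds than are shown below. What is called first, only, known or untested is meant among the compounds shown, and "the series" means these compounds.

In a functional assay on HCT-116 cells (Homo sapiens) for inhibition, read by MTT assay, with a stated time of 48 h (on this read-out higher numbers stand for weaker inhibition and lower numbers for stronger inhibition), compound 1 (`C/C=C/C(=O)N(Cc1ccc(OC)c(OC)c1)c1cc(OC)c(OC)c(OC)c1`) gives 32800 nM and compound 2 (`C/C=C/C(=O)N(Cc1ccc(OC)c(N)c1)c1cc(OC)c(OC)c(OC)c1`) gives 300 nM while compound 3 (`C/C=C/C(=O)N(Cc1ccc(OC)c(Br)c1)c1cc(OC)c(OC)c(OC)c1`) gives 2800 nM and so stands in the middle. Compound 4 (`C/C=C/C(=O)N(Cc1ccc(OC)c(C)c1)c1cc(OC)c(OC)c(OC)c1`) is unmeasured and differs from compound 3 by methyl in place of bromo on an aromatic carbon ortho to a methoxy group. Changes at this carbon gave a 12-fold lower number from compound 1 to compound 3 (1.07 log units; beyond the scatter) for bromo in place of methoxy and a 9.3-fold higher number from compound 2 to compound 3 (0.97 log units; beyond the scatter) for bromo in place of amino, along with a 110-fold lower number from compound 1 to compound 2 (2.04 log units; beyond the scatter) for amino in place of methoxy. For the measured compounds named here, all of these are sizeable, yet no measured compound carries methyl. The expected step, a 1.6-fold higher number from compound 3 to compound 4 (0.21 log units; within the scatter), is estimated to be small. For compound 4 the estimated value is 4500 nM within an expected range from 1000 nM to 15000 nM overall.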

Compound 4, half-maximal inhibitory concentration: 23500 nM
Estimate against measurement, compound 4: 5.2-fold (0.72 log units) below; measured number outside the range, above it.
By their numbers in this assay, from the lowest: compound 2; then compound 3; then compounds 4 and 1 (each within the scatter of the next).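

At this carbon, methyl does not stand in for bromo: the change gives an 8.4-fold higher number from compound 3 to compound 4 (0.92 log units; beyond the scatter) in the measured number, and replacing amino gives a 78-fold higher number from compound 2 to compound 4 (1.89 log units; beyond the scatter) on the same read-out. With a 1.4-fold lower number from compound 1 to compound 4 (0.14 log units; within the scatter) as the step from methoxy, methyl and methoxy cannot be told apart here, so the lower numbers of compound 2 and compound 3 do not extend to every replacement of methoxy. Nothing measured here explains these differences.

As far as these compounds go, how a hydroxyl group, a chlorine atom or a methylamino group would read at this carbon remains open. So does whether an ethyl group would read like methyl.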